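The compounds below may be only part of what the source reports. "The series", "measured", "known", "first", "only" and "open" are said of these compounds alone.

Compound 1 `CSc1ccc(NC(=O)N[C@@H]2C3CCN(CC3)[C@@H]2Cc2cccnc2)cc1` carries a urea on the shared core, and in an assay on a protein complex for binding affinity to Neuronal acetylcholine receptor; alpha4/beta2 (Homo sapiens) (a higher number here means a weaker inhibitor, a lower number a stronger inhibitor), compound 1 gives > 10000 nM, which is a limit of the assay rather than a number. Its two neighbours in this set, compound 2 `O=C(Nc1ccc(Oc2ccccc2)cc1)N[C@@H]1C2CCN(CC2)[C@@H]1Cc1cccnc1` and compound 3 `O=C(Nc1ccc(-c2ccccc2)cc1)N[C@@H]1C2CCN(CC2)[C@@H]1Cc1cccnc1`, share that fate. In this assay compound 2 gives > 10000 nM, again a limit. In this assay compound 3 gives > 10000 nM, also a limit. The steps among them, a step that the two limits leave unreadable from compound 1 to compound 2, a step that the two limits leave unreadable from compound 1 to compound 3 and a step that the two limits leave unreadable from compound 2 to compound 3, therefore cannot be sized, because of the limit of > 10000 nM in this assay, at which 3 of the 3 values shown sit.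

The unmeasured compound 4 `O=C(NCc1ccc(Br)cc1)N[C@@H]1C2CCN(CC2)[C@@H]1Cc1cccnc1` differs from compound 1 by 4-bromobenzyl in place of 4-(methylsulfanyl)phenyl on an amide-type nitrogen. Among the measured compounds shown here, none of the measured steps bears a readable size on this change, so no direction beyond the scatter can be argued from them. Since all three known members of the series sit at the limit, compound 4 is expected to fall at or near it as well, with the step from compound 1 to compound 4 estimated as a step that the limit leaves unreadable from compound 1 to compound 4. For compound 4 the estimate in this assay is 15000 nM, between 3000 nM and 60000 nM.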

Compound 4, inhibition constant: > 10000 nM
Compound 4 gave a limit, no number; the forecaster's own chance of this, stated with the estimate: 75%; the middle value is on the limit's open side.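

Among the compounds shown here, compound 4 also gives only a limit in this assay and so, like compound 1, it yields no step of readable size: the limit of > 10000 nM in this assay, at which 4 of the 4 values shown sit.

The compounds shown leave open whether any other group on the urea gives a readable value in this assay at all.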